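The source may report more compounds than this note shows. Statements on the series, on what has been measured and on what is new or still open speak of the compounds shown alone.

Compound 1 `COc1cc2nccc(O)c2c(O)c1OC` was tested in a functional assay on HL-60 cells (Homo sapiens) for antiproliferative activity; a higher number here means a weaker inhibitor, a lower number a stronger inhibitor. In this assay compound 1 gives > 30000 nM, which is a limit of the assay and not a number. Compound 2 `COc1cc2nccc(O)c2c(OC)c1OC` differs from compound 1 by methyl in place of hydrogen on an oxygen on an aromatic ring. In this assay compound 2 gives > 30000 nM, again a limit. Between the two lies a step that the two limits leave unreadable from compound 1 to compound 2. Compound 3 `COc1cc2c(c(O)c1OC)c(=O)ccn2C` is built on another core; how its core differs from that of compound 1 is not broken down here. In this assay compound 3 gives > 30000 nM, also a limit. Compound 4 `COc1cc2c(c(OC)c1OC)c(=O)ccn2C` has not yet been measured; it differs from compound 3 by methyl in place of hydrogen on an oxygen on an aromatic ring, the same change that separates compound 1 from compound 2. What can be expected for compound 4 rests on (the limit of > 30000 nM in this assay, at which 3 of the 3 values shown sit), together with the unreadable step that the two limits leave unreadable from compound 1 to compound 2. The step from compound 3 to compound 4 is therefore expected to be a step that the limit leaves unreadable from compound 3 to compound 4. Compound 4 is expected to give roughly 40000 nM in this assay, most probably once more as a limit rather than a number.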

Compound 4, half-maximal inhibitory concentration: > 30000 nM
Compound 4 was reported as a limit (the forecaster's own chance of this, stated with the estimate: 85%); the middle value lies beyond the limit too.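

Among these compounds, with compound 3 and compound 4 both reported only as a limit in this assay, the change from hydroxy to methoxy gives no step that can be read from this pair. The compounds shown leave open how strongly any of them acts in this assay, and whether this change affects activity at all.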